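Working notes on the series: compound 2 to compound 4

A few compounds are considered here, and "the series" means these few. Any claim that something is new, unique, unknown or untested is made for them only; others in the source may bear on it.

Three compounds have numbers in a functional assay (aorta) for inhibition, with Homo sapiens as the target, using microsomes, in the presence of a further agent that is not named here; a higher number here means a weaker inhibitor, a lower number a stronger inhibitor. Compound 1 `CCOC(=O)/C=C\c1ccc(Cn2ccnc2)n1C` gives 8900 nM; compound 2 `CCOC(=O)/C(C)=C\c1ccc(Cc2cccnc2)n1CC` gives 14000 nM; compound 3 `CCOC(=O)/C=C/c1cc(Cn2ccnc2)n(C)c1` gives 1800 nM. Compound 2 stands at the high end of these three: its gap to compound 1 lies within the scatter, while compound 3 gives a number lower than compound 2 by a gap beyond the scatter. Among the compounds with values here, no two of the measured compounds differ in only one place, so no step is known from them. Compound 4 `CCOC(=O)/C(C)=C\c1ccc(Cc2cccnc2)n1C(C)C` differs from compound 2 by methyl in place of hydrogen on a saturated chain carbon bound to an aromatic nitrogen and a saturated chain carbon. Nothing in the measured set tests a change of this kind, so the step in this assay is expected to be small, none beyond the scatter in either direction. The expected step is no change at the digits printed from compound 2 to compound 4 (within the scatter). Compound 4 is estimated at 14000 nM, with a range from 6000 nM to 35000 nM.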

Compound 4, half-maximal inhibitory concentration: 32000 nM
Beside the measured number, compound 4's estimate is 2.3-fold (0.36 log units) below it; measured number inside the range.
By their numbers in this assay, from the lowest: compound 3; then compounds 1 and 2 (each within the scatter of the next); then compound 4.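

In this assay the change from ethyl to isopropyl gives a 2.3-fold higher number from compound 2 to compound 4 (0.36 log units; beyond the scatter). Within the data shown here, this is the first step known, and it shows that methyl in place of hydrogen at this carbon, bound to an aromatic nitrogen and a saturated chain carbon, moves the number towards a weaker inhibitor. Nothing at hand accounts for the step. Going by these compounds, whether a longer chain such as butyl, or a chain carrying an amine, would move the number further in the same direction remains open. So does whether the same change gives a similar step on the cores of compound 1 and compound 3.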